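One Added Methoxy Group and an Expected Small Step

The compounds below may be only part of what the source reports. "The series", "measured", "known", "first", "only" and "open" are said of these compounds alone.

For the measured compounds named here, only two compounds have numbers so far, compound 1 `COc1cccc2c1CCC/C2=C\CCN1CCCCC1` and compound 2 `COc1ccc2c(c1)CCC=C2CCCN1CCc2cc(OC)c(OC)cc2C1`. In an ADME assay on Caco-2 cells (Homo sapiens) for permeability, in the apical to basolateral direction (on this read-out higher numbers stand for higher permeability and lower numbers for lower permeability), compound 1 gives 584 nm/s and compound 2 gives 407 nm/s, two values that lie within the usual scatter of each other. Compound 3 `COc1cc2c(cc1OC)CN(CCCC1=CCCc3cc(OC)c(OC)cc31)CC2` differs from compound 2 in one place: methoxy in place of hydrogen on an aromatic carbon. This is methoxy in place of hydrogen on an aromatic carbon, ortho to a methoxy group. Going by the values given here, no pair of measured compounds shows a change of this kind, so the expectation starts from compound 2 at 407 nm/s and foresees no step beyond the scatter in this assay. The expected step is a 1.1-fold lower number from compound 2 to compound 3 (0.04 log units; within the scatter), with no firm direction behind it. In this assay the estimate for compound 3 is 370 nm/s, with an expected range from 190 nm/s to 680 nm/s.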

Compound 3, apparent permeability: 672 nm/s
Estimate against measurement, compound 3: 1.8-fold (0.26 log units) below, and the stated range covers the measured number.
By their numbers in this assay, from the lowest: compounds 2, 1 and 3 (each within the scatter of the next).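

For the compounds shown here, compound 3 gives the first reading of this change: with methoxy in place of hydrogen on this aromatic carbon, ortho to a methoxy group, this assay shows a 1.7-fold higher number from compound 2 to compound 3 (0.22 log units; within the scatter), a step that stays within the scatter. The position therefore takes the added methoxy in this pair without any step that could be told apart from repeat variation, and the added group does not carry the read-out beyond the scatter of compound 2. Nothing available on these compounds speaks to what lies behind this result.

The compounds shown leave open whether an ethoxy group, a fluorine atom or a hydroxyl group on the same carbon would also stay within the scatter. With a single pair, this reading holds only for compound 2 and compound 3, and it cannot yet be carried to other compounds.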